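Nitro in Place of Methoxy: Expecting Little Change

The compounds below may be only part of what the source reports. "The series", "measured", "known", "first", "only" and "open" are said of these compounds alone.

Measured so far:
compound 1, `CCOC(=O)Cc1nc(N)n(C(=O)c2ccc(Cl)cc2)n1`, 34.2%
compound 2, `CCOC(=O)Cc1nc(N)n(C(=O)c2ccc(OC)cc2)n1`, 32.8%

Both were tested in a functional assay on the whole organism (strain albino) for inhibition, with Rattus norvegicus as the target, read by paw edema, with stated times of 30 min and 1 h, at a dose of 5 mg/kg by the oral route; on this read-out lower numbers stand for less inhibition and higher numbers for more inhibition at the one dose given (going by the name of the read-out). Among the compounds with values here, compound 2 holds one of only two numbers, and the single step between them, a number 1.4 percentage points lower from compound 1 to compound 2 (within the scatter), lies within the scatter, so compound 2 stands level with compound 1 rather than apart from it.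

Compound 3, `CCOC(=O)Cc1nc(N)n(C(=O)c2ccc([N+](=O)[O-])cc2)n1`, has not yet been measured. It differs from compound 2 by nitro in place of methoxy on an aromatic carbon. Within the data shown here, the only step that bears on this change is the earlier one, a number 1.4 percentage points lower from compound 1 to compound 2 (within the scatter), where another swap at the same aromatic carbon barely moved the inhibition of paw edema. On that basis no step beyond the scatter is expected in this assay. The expected step is a number 1.2 percentage points higher from compound 2 to compound 3 (within the scatter). Compound 3 is therefore estimated at 34%, with a range from 20% to 48%.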

Compound 3, a percentage reported as inhibition, in the whole organism at one dose (the size of the read-out at that dose, not a potency): 36.1%
Compound 3: middle estimate off by 2.1 percentage points, on the low side; the range from low to high includes it.
By their numbers in this assay, from the lowest: compounds 2, 1 and 3 (each within the scatter of the next).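

In this assay, nitro now joins chloro and methoxy on the same aromatic carbon, para to a large group, and replacing methoxy gives a number 3.3 percentage points higher from compound 2 to compound 3 (within the scatter) while replacing chloro gives a number 1.9 percentage points higher from compound 1 to compound 3 (within the scatter) in this series. Within the data shown here, the earlier pair showed only one swap at this position; these steps show that all three groups, including nitro with its double bond outside aromatic rings, stand level on this read-out at the one dose given. No measurement shown here explains why these groups stand level.

Still open, as far as these compounds go, is whether an amine, a carboxylic acid or a longer chain such as butoxy on this carbon would give a step beyond the usual scatter. Also open, from the compounds shown here alone, is whether these three groups would stay level at another dose, or whether changing the ethyl ester elsewhere on the shared core would matter more.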